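A few compounds are considered here, and "the series" means these few. Any claim that something is new, unique, unknown or untested is made for them only; others in the source may bear on it.

Of the compounds shown here, three built on one shared core have been measured in a functional assay on SNB-19 cells (Homo sapiens) for inhibition, read by sulforhodamine B assay, with a stated time of 48 h, tested at 10 uM; a lower number here means a stronger effect, a higher number a weaker effect of the compound at the concentration tested. Compound 1 `COc1cc(Cl)cc(-c2nn(-c3cccc(NC(=O)c4ccc(Cl)c(Cl)c4)c3)cc2-c2ccncc2)c1` gives 71.6%. Compound 2 `O=C(Nc1cccc(-n2cc(-c3ccncc3)c(-c3cc(O)cc(Cl)c3)n2)c1)Nc1ccc(Cl)c(Cl)c1` gives 30.8%. Compound 3 `COc1cc(Cl)cc(-c2nn(-c3cccc(NC(=O)Nc4ccc(Cl)c(C(F)(F)F)c4)c3)cc2-c2ccncc2)c1` gives 28.1%. Compound 3 thus has the lowest of the three numbers: its nearest neighbour is compound 2, which lies within the usual scatter of repeated measurements, while compound 1 lies far above it. For the measured compounds named here, the one step that can be followed between measured compounds, a number 43.5 percentage points lower from compound 1 to compound 3 (beyond the scatter), changes both the link to the carbonyl carbon and the aryl group on it at once.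

The next compound, compound 4 `COc1cc(Cl)cc(-c2nn(-c3cccc(NC(=O)Nc4ccc(Cl)c(Cl)c4)c3)cc2-c2ccncc2)c1`, has not been measured. It differs from compound 3 in a single place: chloro in place of trifluoromethyl on an aromatic carbon. Going by the values given here, no measured pair shows this particular exchange on its own, so the step from compound 1 to compound 3 does not speak to it directly. Compound 2 carries the same (3,4-dichlorophenyl)amino group that enters here, though it differs from compound 4 elsewhere. Among the compounds with values here, with no directly bearing step, the expectation for compound 4 is a change of a number 1.9 percentage points higher from compound 3 to compound 4 (within the scatter), that is, nothing beyond the scatter. The estimated value for compound 4 in this assay is therefore 30%, with a range from 12% to 55%.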

Compound 4, a percentage reported as activity, at one concentration (the size of the read-out at that concentration, not a potency): 17.8%
Compound 4: the middle estimate sits 12.2 percentage points above what was measured, within the range that was stated.
By their numbers in this assay, from the lowest: compound 4; then compounds 3 and 2 (each within the scatter of the next); then compound 1.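

Chloro in place of trifluoromethyl on this aromatic carbon, ortho to a chloro group, can now be read on its own: in this assay it gives a number 10.3 percentage points lower from compound 3 to compound 4 (beyond the scatter) and so shows that this position responds to the group it carries, although the step is modest. For the compounds shown here, with the 3,4-dichlorophenyl group held fixed, the other two steps separate changes that the earlier compounds could not: (3,4-dichlorophenyl)amino in place of 3,4-dichlorophenyl on the carbonyl carbon gives a number 53.8 percentage points lower from compound 1 to compound 4 (beyond the scatter) and is by far the largest step, while methyl in place of hydrogen on the oxygen gives a number 13 percentage points lower from compound 2 to compound 4 (beyond the scatter) as a second, modest gain. Nothing available here explains why any of these changes has the effect it does.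

Going by these compounds, only trifluoromethyl and chloro appear at this position, so it remains open how a methyl group, a methoxy group, an amine or a carboxylic acid would fare there. It is also open whether the modest gain from chloro would hold with the hydroxyl group of compound 2 on the other ring, and the read-out, taken at a single concentration, gives no potency for any of these compounds.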